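Fluoro and chloro variants on a shared core: working notes

The source may hold more compounds than are shown below. What is called first, only, known or untested is meant among the compounds shown, and "the series" means these compounds.

Compound 3 `CCOc1ccc2nc(Nc3nc4ccccc4s3)sc2c1` is the unsubstituted parent of the set. In a functional assay on B16-F10 cells (Mus musculus) for cytotoxicity, read by MTT assay, with a stated time of 48 h (a lower number here means a stronger inhibitor, a higher number a weaker inhibitor), compound 3 gives only > 50000 nM, which is a limit of the assay and not a number, namely (the limit of > 50000 nM in this assay, at which 1 of the 3 values shown sits). Compound 1 `CCOc1ccc2nc(Nc3nc4ccc(F)cc4s3)sc2c1` carries fluoro in place of hydrogen on an aromatic carbon, and in this assay compound 1 gives 33200 nM, a step of an at least 1.5-fold lower number from compound 3 to compound 1 (0.17 log units; that floor lies within the scatter). Compound 2 `Clc1cccc2sc(Nc3nc4ccccc4s3)nc12` rests on a different core; how that core differs from the core of compound 3 is not broken down here. In this assay compound 2 gives 29500 nM, a value within the scatter of compound 1. Compound 4 `Fc1ccc2nc(Nc3nc4c(Cl)cccc4s3)sc2c1` is not yet measured; it carries fluoro in place of hydrogen on an aromatic carbon, the same change at the same place as before. The step expected is a 1.5-fold lower number from compound 2 to compound 4 (0.17 log units; within the scatter), resting on an at least 1.5-fold lower number from compound 3 to compound 1 (0.17 log units; that floor lies within the scatter). For compound 4 the expected value in this assay is 20000 nM, estimated to lie between 8000 nM and 45000 nM.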

Compound 4, half-maximal inhibitory concentration: > 50000 nM
Compound 4: no number, only a limit; the forecaster's own chance of this, stated with the estimate: 10%; middle value at least 2.5-fold (0.39 log units) from the limit.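

In this assay compound 4 gives > 50000 nM and that is a limit of the assay, not a number. On the core of compound 2, fluoro in place of hydrogen on an aromatic carbon gives an at least 1.6-fold higher number from compound 2 to compound 4 (0.22 log units; that floor lies within the scatter) and so the lower number seen on the core of compound 3 does not recur, although neither floor lies beyond the scatter. This does not show that the change acts differently on the two cores: the same change on two cores in this assay, an at least 1.5-fold lower number (0.17 log units; that floor lies within the scatter) from compound 3 to compound 1 and an at least 1.6-fold higher number (0.22 log units; that floor lies within the scatter) from compound 2 to compound 4; the limit leaves it open whether they differ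

The compounds shown leave open how an amine or a carboxylic acid would read at the place that carries the fluoro. Room for comparison in this series is also narrow: the limit of > 50000 nM in this assay, at which 2 of the 4 values shown sit.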